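Benzyl Ring Change from Compound 3 to Compound 4

This account rests on a few compounds, and the source may have more. Where it says the series, first, only, none or still open, it means among the compounds named here.

Three compounds sharing one core have been measured in an assay on FRT cells for positive allosteric modulation of Cystic fibrosis transmembrane conductance regulator variant N1303K (Homo sapiens), in the presence of a further agent that is not named here; a higher number here means that more compound is needed for the effect, a lower number that less compound is needed:
compound 1 `COc1ccc2[nH]c3c(c2c1)CCNC31CCN(Cc2cc(Cl)ccc2[N+](=O)[O-])CC1` gives 7100 nM
compound 2 `COc1ccc2[nH]c3c(c2c1)CCNC31CCN(Cc2c(F)ccc(Cl)c2F)CC1` gives 1500 nM
compound 3 `COc1ccc2[nH]c3c(c2c1)CCNC31CCN(Cc2ccccc2Cl)CC1` gives 2200 nM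

Compound 3 stands second highest of these three numbers; the nearest step is a 1.5-fold higher number from compound 2 to compound 3 (0.17 log units; within the scatter), the furthest is a 3.2-fold lower number from compound 1 to compound 3 (0.51 log units; beyond the scatter). Compound 4 `COc1ccc2[nH]c3c(c2c1)CCNC31CCN(Cc2ccc(Br)c(F)c2)CC1` differs from compound 3 in one place: 4-bromo-3-fluorophenyl in place of 2-chlorophenyl on a saturated chain carbon bound to an amine nitrogen in a ring. Among the measured compounds shown here, no measured step makes this exact change. For the measured compounds named here, the steps that bear on it are a 4.7-fold lower number from compound 1 to compound 2 (0.68 log units; beyond the scatter) and a 3.2-fold lower number from compound 1 to compound 3 (0.51 log units; beyond the scatter), both modest, while a 1.5-fold higher number from compound 2 to compound 3 (0.17 log units; within the scatter) stays within the scatter. Exchanging one halogenated benzyl for another has so far given only small moves, so the expected step is a 1.1-fold higher number from compound 3 to compound 4 (0.06 log units; within the scatter), within the scatter. Compound 4 is estimated at 2500 nM in this assay, between 900 nM and 7000 nM.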

Compound 4, half-maximal effective concentration: 1800 nM
Compound 4: middle estimate off by 1.4-fold (0.14 log units), on the high side; the measured number falls inside the stated range.
By their numbers in this assay, from the lowest: compounds 2, 4 and 3 (each within the scatter of the next); then compound 1.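

In this assay the 4-bromo-3-fluorophenyl group sits level with both other halogen-only rings on this saturated chain carbon, the steps being (a 1.2-fold lower number from compound 3 to compound 4 (0.09 log units; within the scatter)) and (a 1.2-fold higher number from compound 2 to compound 4 (0.08 log units; within the scatter)). Only 5-chloro-2-nitrophenyl stands apart from it (a 3.9-fold lower number from compound 1 to compound 4 (0.60 log units; beyond the scatter)), so among these four compounds, three quite different halogen patterns give numbers within the scatter of each other. Nothing given here explains this.
From the compounds shown here alone, what an amine or a carboxylic acid on this ring would do remains open. So does whether a longer chain in place of the benzyl link would keep the number in this range.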